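The compounds below may be only part of what the source reports. "The series", "measured", "known", "first", "only" and "open" are said of these compounds alone.

Of the compounds shown here, three built on one shared core have been tested in a functional assay on THP-1 cells (Homo sapiens) for cytotoxicity, read by MTT assay, with a stated time of 24 h; on this read-out lower numbers stand for stronger inhibition and higher numbers for weaker inhibition. Compound 1 `CN1C/C(=C\c2ccc(Br)cc2)C(=O)/C(=C/c2cccc([N+](=O)[O-])c2)C1` gives 7690 nM. Compound 2 `CN1C/C(=C\c2ccc(C(F)(F)F)cc2)C(=O)/C(=C/c2cccc([N+](=O)[O-])c2)C1` gives 970 nM. Compound 3 `CN1C/C(=C\c2ccc(Br)cc2)C(=O)/C(=C/c2ccc(C#N)cc2)C1` gives 4400 nM. Between compound 1 and compound 2 the measured step is a 7.9-fold lower number from compound 1 to compound 2 (0.90 log units; beyond the scatter), and the structural change behind it is trifluoromethyl in place of bromo on an aromatic carbon. Compound 4 `CN1C/C(=C\c2ccc(C#N)cc2)C(=O)/C(=C/c2ccc(C(F)(F)F)cc2)C1` has not yet been measured; it differs from compound 3 by trifluoromethyl in place of bromo on an aromatic carbon, the same change as the one from compound 1 to compound 2, which is thus made twice among these compounds. The difference between the core of compound 1 and the core of compound 3 is not broken down here. For compound 4 in this assay the expected step is a 4.0-fold lower number from compound 3 to compound 4 (0.60 log units; beyond the scatter), somewhat smaller than the earlier one, because a 7.9-fold lower number from compound 1 to compound 2 (0.90 log units; beyond the scatter) rests on a single pair and a second pair may not repeat it in full. Compound 4 is therefore estimated to give 1100 nM, with a likely range from 400 nM to 3500 nM.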

Compound 4, half-maximal inhibitory concentration: 1430 nM
Compound 4: the middle estimate sits 1.3-fold (0.11 log units) below what was measured; the measured number falls inside the stated range.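

In this assay, trifluoromethyl in place of bromo on an aromatic carbon goes the same way on the second core as on the first, with a 3.1-fold lower number from compound 3 to compound 4 (0.49 log units; beyond the scatter). Within the data shown here, the size of the step also carries over as far as these data can tell, since the two steps stay within the scatter of each other: the same change on two cores in this assay, a 7.9-fold lower number (0.90 log units; beyond the scatter) from compound 1 to compound 2 and a 3.1-fold lower number (0.49 log units; beyond the scatter) from compound 3 to compound 4, 2.6-fold (0.41 log units) apart, within the scatter of two such steps This is only two pairs, so it gives no exact size for the step, does not explain why the numbers fall, and says nothing about cores beyond these, while the swap of 4-cyanophenyl in place of 3-nitrophenyl gives a 1.5-fold higher number from compound 2 to compound 4 (0.17 log units; within the scatter), which cannot be told apart from repeat scatter.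

On these data alone, it remains open whether the change would hold on a third core. Also open, as far as these compounds go, is how other groups on that aromatic carbon, such as a methoxy group, an amine or a carboxylic acid, would compare with bromo and trifluoromethyl.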